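Nitro for trifluoromethyl: lipophilicity notes on the series

The source may hold more compounds than are shown below. What is called first, only, known or untested is meant among the compounds shown, and "the series" means these compounds.

Measured so far:
compound 1, `O=C(Nc1cccc(C(F)(F)F)c1)c1ccc2cccc(O)c2n1`, 2.5
compound 2, `O=C(Nc1ccc(C(F)(F)F)cc1)c1ccc2cccc(O)c2n1`, 2.5
compound 3, `O=C(Nc1cccc([N+](=O)[O-])c1)c1ccc2cccc(O)c2n1`, 2.5

The read-out is a physicochemical assay for lipophilicity, read by HPLC; on this read-out lower numbers stand for lower lipophilicity and higher numbers for higher lipophilicity. Compound 1 and compound 2 are built from the same atoms joined differently; the difference between the two cores is not broken down here. In this assay compound 2 stands level with compound 1 and compound 3, and the three values lie within the usual scatter of one another.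

One change has been measured once: nitro in place of trifluoromethyl on an aromatic carbon, with the step of no change at the digits printed from compound 1 to compound 3 (within the scatter).

Compound 4, `O=C(Nc1ccc([N+](=O)[O-])cc1)c1ccc2cccc(O)c2n1`, remains unmeasured. It differs from compound 2 by nitro in place of trifluoromethyl on an aromatic carbon. This is the same kind of change as that from compound 1 to compound 3, not the same one: there the entering group sits meta to a large group, here para to a large group.

For the measured compounds named here, the expectation for compound 4 rests on the single measured step from compound 1 to compound 3; the estimated step is no change at the digits printed from compound 2 to compound 4 (within the scatter). Compound 4 is therefore expected at 2.5, with an estimated range from 2.1 to 2.9.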

Compound 4, partition coefficient: 2.5
Beside the measured number, compound 4's estimate shows no gap at the digits printed; the range from low to high includes it.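

In this assay, nitro in place of trifluoromethyl gives no change at the digits printed from compound 2 to compound 4 (within the scatter), and the same kind of change on the other core gives no change at the digits printed from compound 1 to compound 3 (within the scatter), so within these two pairs the change carries from one core to the other with the same reading. This rests on two steps only, and a step within the scatter cannot tell a true absence of change from a small change hidden inside it, so no rule for the series follows beyond these four compounds. Nothing available bears on why the two steps agree.

The compounds shown leave open whether the same reading holds for other groups in this place, such as an amine, a carboxylic acid or a longer chain, whose values cannot be inferred from these four compounds. As far as these compounds go, whether the swap of nitro for trifluoromethyl reads the same on a different core also remains open.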